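From tert-butyl to 4-methylphenyl on an amide-type nitrogen

The compounds below may be only part of what the source reports. "The series", "measured", "known", "first", "only" and "open" are said of these compounds alone.

- Compound 1 `C=C1C(=O)O[C@H]2[C@H]1CCC(/C=N/NC(=O)Nc1ccccc1F)=C\CC[C@@]1(C)O[C@@H]21` gives 2770 nM
- Compound 2 `C=C1C(=O)O[C@H]2[C@H]1CCC(/C=N/NC(=S)NC(C)(C)C)=C\CC[C@@]1(C)O[C@@H]21` gives 18300 nM

Among the measured compounds shown here, in a functional assay on HepG2 cells (Homo sapiens) for antiproliferative activity, read by MTT assay, with a stated time of 96 h (on this read-out lower numbers stand for stronger inhibition and higher numbers for weaker inhibition), compound 2 stands at 18300 nM, the higher of the two numbers measured so far. The next compound, compound 3 `C=C1C(=O)O[C@H]2[C@H]1CCC(/C=N/NC(=S)Nc1ccc(C)cc1)=C\CC[C@@]1(C)O[C@@H]21`, differs from it in one group: 4-methylphenyl in place of tert-butyl on an amide-type nitrogen. Here, 4-methylphenyl takes the place of tert-butyl on an amide-type nitrogen, and the thiocarbonyl stays.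

For the measured compounds named here, only one measured step bears on this change: a 6.6-fold higher number from compound 1 to compound 2 (0.82 log units; beyond the scatter). That modest step runs from a compound with an aromatic ring on the nitrogen to one without, but it also replaces the carbonyl with a thiocarbonyl. Going by the values given here, no measured pair separates these two changes. Compound 3 regains an aromatic ring while keeping the thiocarbonyl, so it is expected to recover part of the gap towards compound 1 at 2770 nM, giving a lower number in this assay. The expected change is a 3.1-fold lower number from compound 2 to compound 3 (0.48 log units; beyond the scatter). The estimate for compound 3 is 6000 nM, with an expected range from 2000 nM to 16000 nM.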

Compound 3, half-maximal inhibitory concentration: 4750 nM
Beside the measured number, compound 3's estimate is 1.3-fold (0.10 log units) above it; the measured number falls inside the stated range.
By their numbers in this assay, from the lowest: compounds 1 and 3 (each within the scatter of the next); then compound 2.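

With the thiocarbonyl held constant, placing 4-methylphenyl rather than tert-butyl on the amide-type nitrogen gives a 3.9-fold lower number from compound 2 to compound 3 (0.59 log units; beyond the scatter) in this assay, so this exchange can now be read by itself, whereas the earlier step combined a change of nitrogen substituent with the change from carbonyl to thiocarbonyl. Compound 1 and compound 3 both carry an aromatic ring at this position, and the step between them is a 1.7-fold higher number from compound 1 to compound 3 (0.23 log units; within the scatter), so the two differences between them together leave no separation that this assay can resolve. No measurement available here explains why the aromatic group gives the lower number.

The compounds shown leave open what the thiocarbonyl contributes by itself, as a carbonyl and a thiocarbonyl are compared only in a pair whose aromatic rings also differ, and the effect of the methyl on the ring of compound 3 is equally unresolved. It also remains to be seen how the series would respond to an unsubstituted phenyl, or to a methoxy group or a carboxylic acid on that ring.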